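Cytotoxicity notes: benzyl substitution on the shared core

The compounds below may be only part of what the source reports. "The series", "measured", "known", "first", "only" and "open" are said of these compounds alone.

Compound 1 `Cc1c(Cc2ccccc2)c(=O)oc2cc(OCC(O)CNc3nccs3)ccc12` gives in an ADME assay on A549 cells (Homo sapiens) for cytotoxicity, read by CellTiter-Glo (on this read-out higher numbers stand for lower toxicity in this test and lower numbers for higher toxicity in this test), a half-maximal cytotoxic concentration of 93000 nM. Compound 2 `Cc1cc(=O)oc2cc(OCC(O)CN3CCC(C(N)=O)CC3)ccc12` reaches only a limit of > 100000 nM in this assay. Compound 2 therefore stands at the limit of > 100000 nM in this assay, at which 1 of the 2 values shown sits, with no number behind it. Compound 3 `Cc1c(Cc2cccc(F)c2)c(=O)oc2cc(OCC(O)CN3CCC(C(N)=O)CC3)ccc12` is not yet measured in this assay; it differs from compound 2 by 3-fluorobenzyl in place of hydrogen on an aromatic carbon. Going by the values given here, no measured pair differing in one place exists here, so the size of this step is unknown. Compound 1, which carries a benzyl group and a different chain, also shows low toxicity with its value of 93000 nM. The step from compound 2 to compound 3 is expected to be an at least 1.2-fold lower number from compound 2 to compound 3 (0.09 log units; that floor lies within the scatter), at most a modest move toward higher toxicity. Compound 3 is expected to give 80000 nM, between 30000 nM and 150000 nM, with a fair chance of another limit.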

Compound 3, half-maximal cytotoxic concentration: 53300 nM
The estimate for compound 3 lay 1.5-fold (0.18 log units) above the measured number; low and high end bracket the measured number.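

In this assay, going by these compounds alone, 3-fluorobenzyl in place of hydrogen on an aromatic carbon gives the first step that can be read at this position: an at least 1.8-fold lower number from compound 2 to compound 3 (0.27 log units; that floor lies within the scatter). With the chain of compound 2 kept, the added group yields a measured number on this chain, where compound 2 itself has none. Only a floor can be stated, and it does not establish a change beyond the scatter, because compound 2 stands at a limit: the limit of > 100000 nM in this assay, at which 1 of the 3 values shown sits.

The compounds shown leave open how an unsubstituted benzyl, a 4-fluorobenzyl or a longer phenethyl chain at this position would compare on the chain of compound 2, so the share of the fluorine in this step cannot be told. Compound 1 differs from compound 3 in more than one place and does not settle this.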